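This account rests on a few compounds, and the source may have more. Where it says the series, first, only, none or still open, it means among the compounds named here.

Compound 3 `O=C(O)CCCC/C=C(\c1cccnc1)c1cccs1` gives 20 nM in an assay (Equus caballus) for inhibition of Thromboxane-A synthase (Homo sapiens), using microsomes (a lower number here means a stronger inhibitor, a higher number a weaker inhibitor), the lowest of the three numbers measured. Compound 1 `O=C(O)C(CCC/C=C(/c1cccnc1)c1cccs1)c1ccccc1` gives 32 nM, within the scatter of compound 3, so no order between them can be claimed. Compound 2 `O=C(O)CCCC/C=C(/c1ccc(F)cc1)c1cccnc1` gives 83 nM, and the step of a 4.2-fold lower number from compound 2 to compound 3 (0.62 log units; beyond the scatter) is beyond the scatter. Compound 4 `O=C(O)C(CCC/C=C(\c1cccnc1)c1cccs1)c1ccccc1` differs from compound 3 by phenyl in place of hydrogen on a saturated chain carbon bound to a carbonyl carbon and a saturated chain carbon. Going by the values given here, no measured pair differs only in this way; compound 1 carries the same phenyl but also a different double-bond geometry, and its number and that of compound 3 sit within the scatter of each other. The step of a 1.3-fold higher number from compound 3 to compound 4 (0.10 log units; within the scatter) is therefore expected to stay within the scatter. Compound 4 is estimated at 25 nM in this assay, with a range from 10 nM to 60 nM.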

Compound 4, half-maximal inhibitory concentration: 50 nM
Estimate against measurement, compound 4: 2.0-fold (0.30 log units) below, within the range that was stated.
By their numbers in this assay, from the lowest: compounds 3, 1, 4 and 2 (each within the scatter of the next, the first and the last beyond it).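

In this assay, phenyl in place of hydrogen on a saturated chain carbon bound to a carbonyl carbon and a saturated chain carbon can now be read as a single change, and it gives a modest step beyond the scatter: a 2.5-fold higher number from compound 3 to compound 4 (0.40 log units; beyond the scatter). With that phenyl present, double-bond geometry gives no order, with a 1.6-fold higher number from compound 1 to compound 4 (0.19 log units; within the scatter), so the two arrangements cannot be told apart here. This comparison carries a caution about how the structures are drawn: the fact that one of compounds 1 and 4 is drawn with a defined configuration and the other without, at the place where they differ

As far as these compounds go, whether a methyl group on this same carbon would give a step of similar size remains open. So does whether the phenyl step would hold with 4-fluorophenyl in place of thiophen-2-yl.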